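A few compounds are considered here, and "the series" means these few. Any claim that something is new, unique, unknown or untested is made for them only; others in the source may bear on it.

In an ADME assay on HEK-293T cells (Homo sapiens) for cytotoxicity, with a stated time of 72 h (on this read-out higher numbers stand for lower toxicity in this test and lower numbers for higher toxicity in this test), the three measured compounds stand as follows:

compound 1 `CCCC[C@H]1CC[C@H](OC(=O)N[C@@H](CC(C)C)C(=O)N[C@H](C=O)C[C@@H]2CCNC2=O)CC1` gives 55000 nM
compound 2 `CCCC[C@H]1CC[C@H](OC(=O)N[C@@H](CC(C)C)C(=O)N[C@@H](C[C@@H]2CCNC2=O)C(O)S(=O)(=O)O)CC1` gives 58000 nM
compound 3 `CC(C)C[C@H](NC(=O)OC(Cc1ccccc1)C1CCC(F)(F)CC1)C(=O)N[C@H](C=O)C[C@@H]1CCNC1=O` gives only a limit of the assay, > 100000 nM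

Compound 1 and compound 2 share one core, while compound 3 is built on a different core; the difference between the two cores is not broken down here. Within the first core the only change is hydroxy(sulfo)methyl in place of formyl on a saturated chain carbon bound to an amide-type nitrogen and a saturated chain carbon. The measured step, a 1.1-fold higher number from compound 1 to compound 2 (0.02 log units; within the scatter), leaves the read-out essentially where it was.

Compound 4 `CC(C)C[C@H](NC(=O)OC(Cc1ccccc1)C1CCC(F)(F)CC1)C(=O)N[C@@H](C[C@@H]1CCNC1=O)C(O)S(=O)(=O)O` has not yet been measured in this assay. It carries the same change, now on the core of compound 3, namely (hydroxy(sulfo)methyl in place of formyl on a saturated chain carbon bound to an amide-type nitrogen and a saturated chain carbon). For compound 3 itself only a limit is known: the limit of > 100000 nM in this assay, at which 1 of the 3 values shown sits.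

Because the same change gave a 1.1-fold higher number from compound 1 to compound 2 (0.02 log units; within the scatter), a comparably small move is expected when it is made on the second core. The expected step is estimated as a step that the limit leaves unreadable from compound 3 to compound 4. Compound 4 is therefore expected to give about 120000 nM, most likely between 60000 nM and 250000 nM, and it is quite possible that this assay will again report only a limit rather than a number.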

Compound 4, half-maximal cytotoxic concentration: > 100000 nM
Compound 4 was reported as a limit; the forecaster's own chance of this, stated with the estimate: 65%; the middle value is on the limit's open side.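

Compound 3 and compound 4 are both reported only as a limit, not as a number: the limit of > 100000 nM in this assay, at which 2 of the 4 values shown sit. No size can therefore be read for the step between them. The compounds shown leave open whether hydroxy(sulfo)methyl in place of formyl changes the read-out in this assay on the core of compound 3, as little as it does on the core of compound 1.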